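Carboxy for methoxy: expected inhibition of compound 4

The compounds below may be only part of what the source reports. "The series", "measured", "known", "first", "only" and "open" are said of these compounds alone.

Compound 2 `COc1ccc(NC(=O)c2ccc(CNc3nccc(-c4cccnc4)n3)cc2)c(N)c1` gives in an assay for inhibition of histone deacetylase 8 (Homo sapiens), read by fluorescence, with stated times of 15 min and 60 min (a higher number here means a weaker inhibitor, a lower number a stronger inhibitor), only a limit, > 20000 nM, so its position is not resolved beyond that. Compound 1 `Nc1cc(-c2ccccc2)ccc1NC(=O)c1ccc(CNc2nccc(-c3cccnc3)n2)cc1` likewise gives only a limit, > 20000 nM. Going by the values given here, compound 3 `CC(=O)N1C(NCc2ccc(C(=O)Nc3ccccc3N)cc2)=NC(=O)C1Cc1ccccc1` gives 22700 nM, the one numerical value in the set. Among the compounds with values here, the single one-point step, a step that the two limits leave unreadable from compound 1 to compound 2, therefore cannot be sized. Compound 4 `Nc1cc(C(=O)O)ccc1NC(=O)c1ccc(CNc2nccc(-c3cccnc3)n2)cc1` differs from compound 2 by carboxy in place of methoxy on an aromatic carbon. Within the data shown here, no measured step bears directly on an exchange of methoxy for carboxy at this position; the only step available is unreadable, and the series as a whole sits at or near the limit, as the limit of > 20000 nM in this assay, at which 2 of the 3 values shown sit, records. The expectation for compound 4 is accordingly no change beyond the scatter, a step that the limit leaves unreadable from compound 2 to compound 4, with a high chance that this assay again returns only a limit. The estimate for compound 4 is 25000 nM, with a range from 8000 nM to 80000 nM.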

Compound 4, half-maximal inhibitory concentration: > 20000 nM
Compound 4 ended at the assay's limit; the forecaster's own chance of this, stated with the estimate: 70%; the middle value lies beyond the limit too.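

In (this assay) compound 4 gives only a limit (> 20000 nM), so no new step can be read from compound 2 or compound 1 to compound 4, since the series sits at the assay's ceiling: the limit of > 20000 nM in this assay, at which 3 of the 4 values shown sit.

On these data alone, whether methoxy, phenyl or carboxy on this aromatic carbon changes inhibition at all remains open.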